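This account rests on a few compounds, and the source may have more. Where it says the series, first, only, none or still open, it means among the compounds named here.

Compound 3 `C[S+]([O-])/C=C/c1cc(=O)c2ccccc2o1` sits on the bare core of this small series. In a functional assay on A549 cells (Homo sapiens) for cytotoxicity, with a stated time of 48 h (on this read-out lower numbers stand for stronger inhibition and higher numbers for weaker inhibition), compound 3 gives 1900 nM, the highest of the two numbers shown, though compound 1 `CCCOc1ccc2oc(/C=C/[S+](C)[O-])cc(=O)c2c1` with 1100 nM stands very near: a 1.7-fold higher number from compound 1 to compound 3 (0.24 log units; within the scatter). Compound 2 `C[S+]([O-])/C=C/c1cc(=O)c2cc(C#N)ccc2o1` reaches only a limit of the assay, > 10000 nM, and this is the limit of > 10000 nM in this assay, at which 1 of the 3 values shown sits. The cyano-bearing compound 2 therefore stands apart from both of its neighbours, with an at least 9.0-fold higher number from compound 1 to compound 2 (0.95 log units; beyond the scatter) and an at least 5.2-fold lower number from compound 2 to compound 3 (0.72 log units; beyond the scatter). Compound 4 `COc1ccc2c(=O)cc(/C=C/[S+](C)[O-])oc2c1` now carries methoxy in place of hydrogen on an aromatic carbon. The step that bears on this change is the exchange of propoxy for hydrogen between compound 1 and compound 3, which gave a 1.7-fold higher number from compound 1 to compound 3 (0.24 log units; within the scatter), a move within the scatter. The two cyano steps concern a different group and do not inform a methoxy. Compound 4 is accordingly expected to show no step beyond the scatter, with at most a slight drift toward lower numbers, a 1.5-fold lower number from compound 3 to compound 4 (0.16 log units; within the scatter). The estimate for compound 4 in this assay is 1300 nM, lying between 500 nM and 3500 nM.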

Compound 4, half-maximal inhibitory concentration: 2200 nM
Compound 4: the middle estimate sits 1.7-fold (0.23 log units) below what was measured, and the stated range covers the measured number.
By their numbers in this assay, from the lowest: compounds 1, 3 and 4 (each within the scatter of the next). At a limit, above all of these: compound 2.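

In this assay, methoxy in place of hydrogen on this aromatic carbon, meta to a fused ring and para to a fused ring, leaves the read-out essentially unchanged: a 1.2-fold higher number from compound 3 to compound 4 (0.06 log units; within the scatter). Among these compounds, the earlier compounds carried their groups elsewhere on the shared core, so this is the first sign that this carbon tolerates a small oxygen-linked group with no change beyond the scatter. The compounds shown offer no account of why the step is so small.

One flat step at one place does not describe this position as a whole. Going by these compounds, whether a longer chain such as butoxy, an amine or a carboxylic acid on this same carbon would keep the number within the scatter remains open, as does the effect of a nitrile here.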